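The compounds below may be only part of what the source reports. "The series", "measured", "known", "first", "only" and "open" are said of these compounds alone.

In an ADME assay on H9c2 cells (Rattus norvegicus) for cytotoxicity (on this read-out higher numbers stand for weaker inhibition and lower numbers for stronger inhibition), compound 1, `CN(C(=O)C1CC1)c1nc2ccc(Cl)cc2s1`, gives > 50000 nM, which is a limit of the assay and not a number. Compound 2, `CCN(C(=O)C1CC1)c1nc2ccc(Cl)cc2s1`, gives > 50000 nM, and this too is a limit. Compound 2 therefore stands at the limit of > 50000 nM in this assay, at which 2 of the 2 values shown sit, with no exact number to start from.

Compound 3, `CCCCN(C(=O)C1CC1)c1nc2ccc(Cl)cc2s1`, differs from compound 2 by ethyl in place of hydrogen on a saturated chain carbon, two bonds along the chain from an amide-type nitrogen. In words, this is ethyl in place of hydrogen on a saturated chain carbon, two bonds along the chain from an amide-type nitrogen, so that ethyl becomes butyl.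

Going by the values given here, the one measured step that bears on this change is a step that the two limits leave unreadable from compound 1 to compound 2, where methyl replaces hydrogen on a saturated chain carbon bound to an amide-type nitrogen. Its size cannot be read, so it offers no size to carry forward, and it gives no direction either. Among the compounds with values here, with only that step to go on, no change beyond the usual scatter is expected in this assay.

The estimated change is a number no higher from compound 2 to compound 3 (the limit leaves the size open).

For compound 3 the expected value is 50000 nM, with an estimated range from 20000 nM to 100000 nM.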

Compound 3, half-maximal inhibitory concentration: > 50000 nM
Compound 3: no number, only a limit; the forecaster's own chance of this, stated with the estimate: 70%; the middle value lies on the limit itself.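

Compound 1, compound 2 and compound 3 all give a limit of the assay and not a number, so no step among them can be read in this assay: the limit of > 50000 nM in this assay, at which 3 of the 3 values shown sit.

The compounds shown leave open whether methyl, ethyl and butyl on the amide-type nitrogen differ at all in this assay, and by how much.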